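Hydroxamate versus trifluoromethyl ketone pair on the aryl-oxadiazole chain

The compounds below may be only part of what the source reports. "The series", "measured", "known", "first", "only" and "open" are said of these compounds alone.

Measured so far:
compound 1 `O=C(CCCCCCc1nc(-c2ccc(C(F)(F)F)cc2)no1)NO`, 14000 nM
compound 2 `O=C(CCCCCCc1nc(-c2ccc(F)cc2)no1)NO`, 5770 nM
compound 3 `O=C(CCCCCCc1nc(-c2ccc(C(F)(F)F)cc2)no1)C(F)(F)F`, 28800 nM

The read-out throughout is a functional assay on A549 cells (Homo sapiens) for antiproliferative activity, read by MTT assay, with a stated time of 72 h; a lower number here means a stronger inhibitor, a higher number a weaker inhibitor. Compound 1 gives 14000 nM. Compound 2 differs from it by fluoro in place of trifluoromethyl on an aromatic carbon and gives 5770 nM; the step is a 2.4-fold lower number from compound 1 to compound 2 (0.38 log units; beyond the scatter). Compound 3 carries a different chain end, (trifluoromethyl in place of hydroxyamino on a carbonyl carbon), and gives 28800 nM, a step of a 2.1-fold higher number from compound 1 to compound 3 (0.31 log units; beyond the scatter). Of the three numbers that of compound 3 is the highest.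

Compound 4 `O=C(CCCCCCc1nc(-c2ccc(F)cc2)no1)C(F)(F)F` is not yet measured. It stands to compound 3 as compound 2 stands to compound 1: fluoro in place of trifluoromethyl on an aromatic carbon. The place lines read the same word for word, so this is the same change made once on the hydroxyamino core and once on the trifluoromethyl core. In the measured pair it moved the number down by a 2.4-fold lower number from compound 1 to compound 2 (0.38 log units; beyond the scatter). Among the measured compounds shown here, a step of about the same size is expected here, a 2.4-fold lower number from compound 3 to compound 4 (0.38 log units; beyond the scatter), because compound 3 starts at 28800 nM and only one such example exists. Compound 4 is therefore estimated at 12000 nM, within 5000 nM to 30000 nM.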

Compound 4, half-maximal inhibitory concentration: > 100000 nM
Compound 4 was reported as a limit; the forecaster's own chance of this, stated with the estimate: 10%; at least 8.3-fold (0.92 log units) between middle value and limit.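

With an at least 3.4-fold higher number from compound 3 to compound 4 (0.54 log units; beyond the scatter), fluoro in place of trifluoromethyl on the aromatic carbon does not carry over from the hydroxyamino core to the trifluoromethyl core in this assay: the same change on two cores in this assay, a 2.4-fold lower number (0.38 log units; beyond the scatter) from compound 1 to compound 2 and an at least 3.4-fold higher number (0.54 log units; beyond the scatter) from compound 3 to compound 4, at least 8.4-fold (0.92 log units) apart, beyond the scatter of two such steps

Read the other way round, the chain-end change also depends on the core, with an at least 17-fold higher number from compound 2 to compound 4 (1.23 log units; beyond the scatter): the same change on two cores in this assay, a 2.1-fold higher number (0.31 log units; beyond the scatter) from compound 1 to compound 3 and an at least 17-fold higher number (1.23 log units; beyond the scatter) from compound 2 to compound 4, at least 8.4-fold (0.92 log units) apart, beyond the scatter of two such steps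

Compound 4 is recorded as a limit of the assay, > 100000 nM, so the full size of both steps to it is not shown, and a single pair of cores gives no rule for any other core.

On these data alone, it remains open whether the same dependence on the core would appear with chloro or methoxy on the aromatic carbon. A carboxylic acid at the chain end, or a shorter or longer chain carrying either existing end group, is also left untested by the compounds shown here.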